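Restoring the Oxygen Position While Unmasking a Hydroxyl

The source may report more compounds than this note shows. Statements on the series, on what has been measured and on what is new or still open speak of the compounds shown alone.

Of the compounds shown here, two sharing one core have been measured in a functional assay on A549 cells (Homo sapiens) for inhibition, read by MTT assay, with a stated time of 24 h; a higher number here means a weaker inhibitor, a lower number a stronger inhibitor. Compound 1 `COc1ccc(-n2cc(CN3C(=O)C[C@@H]4CC[C@@]3(C)C4(C)C)nn2)cc1` carries a 4-methoxyphenyl and gives 50 nM. Compound 2 `COc1cccc(-n2cc(CN3C(=O)C[C@@H]4CC[C@@]3(C)C4(C)C)nn2)c1` carries a 3-methoxyphenyl instead and gives 240 nM. For the measured compounds named here, the single measured step, a 4.8-fold higher number from compound 1 to compound 2 (0.68 log units; beyond the scatter), shows that relocating the methoxy group on this ring weakens inhibition. Compound 2 thus stands as the higher of the two numbers, with compound 1 the nearest and only comparison.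

Compound 3 `CC1(C)[C@H]2CC[C@]1(C)N(Cc1cn(-c3ccc(O)cc3)nn1)C(=O)C2` has not yet been measured. Its change from compound 2 is 4-hydroxyphenyl in place of 3-methoxyphenyl on an aromatic nitrogen. Two things happen at once: the ring again bears its oxygen as in the 4-methoxyphenyl of compound 1, and the methyl is gone, leaving a hydroxyl that counts as a hydrogen-bond donor. Going by the values given here, only the step from compound 1 to compound 2 bears on this, and only on the first of the two changes; it was of modest size and disfavoured the 3-methoxyphenyl. Nothing measured speaks to the loss of the methyl. The expected outcome is therefore a lower number, with a 3.0-fold lower number from compound 2 to compound 3 (0.48 log units; beyond the scatter), less certain than the measured step. Compound 3 is estimated at 80 nM, within a range of 25 nM to 300 nM.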

Compound 3, half-maximal inhibitory concentration: 140 nM
For compound 3 the middle estimate is 1.8-fold (0.24 log units) below the measured one; low and high end bracket the measured number.
By their numbers in this assay, from the lowest: compound 1; then compounds 3 and 2 (each within the scatter of the next).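

Comparing two compounds with the oxygen at the same ring position isolates the methyl for the first time: in this assay, removing it to leave a hydroxyl gives a 2.8-fold higher number from compound 1 to compound 3 (0.45 log units; beyond the scatter), so at this position the 4-methoxyphenyl of compound 1 is better than the 4-hydroxyphenyl, and compound 1 remains the strongest inhibitor of the three. The other step, a 1.7-fold lower number from compound 2 to compound 3 (0.23 log units; within the scatter), leaves compound 2 and compound 3 indistinguishable in this assay, so a 4-hydroxyphenyl and a 3-methoxyphenyl on the aromatic nitrogen cannot be ranked against each other here. No measurement is available to explain why either step has the size it has.

The 3-hydroxyphenyl would complete the set, showing whether removing the methyl costs as much with the oxygen at the other ring position as it does in the step above. On these data alone, it also remains open whether the methyl is the best group on this oxygen, since an ethyl or a longer chain there, or an amine in place of the hydroxyl, could give a number on either side of that of compound 1.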